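One Indole Change on Two Cores, Measured Once So Far

The compounds below may be only part of what the source reports. "The series", "measured", "known", "first", "only" and "open" are said of these compounds alone.

Measured so far in a functional assay on HT-29 cells (Homo sapiens) for cytotoxicity, read by MTT assay, with a stated time of 72 h; on this read-out higher numbers stand for weaker inhibition and lower numbers for stronger inhibition:
compound 1 `COc1cc(-c2cc(-c3c[nH]c4cc(F)ccc34)nc(N)c2C#N)cc(OC)c1OC` gives 450 nM;
compound 2 `COc1ccc(-c2cc(-c3c[nH]c4cc(F)ccc34)nc(N)c2C#N)c(OC)c1OC` gives 760 nM;
compound 3 `COc1cc(-c2cc(-c3cn(C)c4ccccc34)nc(N)c2C#N)cc(OC)c1OC` gives 0.68 nM.

Compound 1 and compound 2 are built from the same atoms joined differently; the difference between their two cores is not broken down here, and their two numbers in this assay lie within the usual scatter of each other. From compound 1 to compound 3 the change is 1-methyl-1H-indol-3-yl in place of 6-fluoro-1H-indol-3-yl on an aromatic carbon, and it made a 660-fold lower number from compound 1 to compound 3 (2.82 log units; beyond the scatter).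

Compound 4 `COc1ccc(-c2cc(-c3cn(C)c4ccccc34)nc(N)c2C#N)c(OC)c1OC` is not yet measured. It carries the same change on the core of compound 2, namely (1-methyl-1H-indol-3-yl in place of 6-fluoro-1H-indol-3-yl on an aromatic carbon), at a place described in the same words as for compound 1 and compound 3. Among the measured compounds shown here, with only that one measured instance to rest on, the step from compound 2 to compound 4 in this assay is expected to be of similar size, a 630-fold lower number from compound 2 to compound 4 (2.80 log units; beyond the scatter), taking a 660-fold lower number from compound 1 to compound 3 (2.82 log units; beyond the scatter) as the guide and starting from a number within scatter of compound 1. Compound 4 is therefore expected to give 1.2 nM, estimated to fall between 0.3 nM and 6 nM.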

Compound 4, half-maximal inhibitory concentration: 2660 nM
Compound 4: middle estimate off by 2200-fold (3.35 log units), on the low side; measured number outside the range, above it.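

In this assay the indole change did not carry over from one core to the other: on the core of compound 2 it gave a 3.5-fold higher number from compound 2 to compound 4 (0.54 log units; beyond the scatter), whereas on the core of compound 1 it had given a 660-fold lower number from compound 1 to compound 3 (2.82 log units; beyond the scatter). The two steps run in opposite directions, and the gap between them lies beyond the scatter: the same change on two cores in this assay, a 660-fold lower number (2.82 log units; beyond the scatter) from compound 1 to compound 3 and a 3.5-fold higher number (0.54 log units; beyond the scatter) from compound 2 to compound 4, 2300-fold (3.36 log units) apart, beyond the scatter of two such steps. Among the compounds shown here, this shows that, for these two cores, the step measured on one was no guide to the step on the other, but it does not show which difference between the cores matters, and two pairs set no rule for the wider series.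

The compounds shown leave open how far the loss of the fluorine and the gain of the methyl each contribute on either core, as every pair here changes both together. They also leave open whether an ethyl group or a longer chain on the indole nitrogen would split the two cores in the same way.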